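Cyclohexyl in place of phenyl on the chain carbon

The source may report more compounds than this note shows. Statements on the series, on what has been measured and on what is new or still open speak of the compounds shown alone.

Three compounds have so far been measured in a toxicity assay on THP-1 cells (Homo sapiens) for cytotoxicity, read by MTT assay, with a stated time of 72 h; a higher number here means that more compound is needed for the effect, a lower number that less compound is needed:

Compound 1 `Cc1ccc(/C=N/NC(N)=S)c2ccccc12` gives 32000 nM.
Compound 2 `CCCCOc1ccc(/C=N/NC(N)=S)c2ccccc12` gives > 200000 nM, which is a limit of the assay.
Compound 3 `NC(=S)N/N=C/c1ccc(OCc2ccccc2)c2ccccc12` gives 27000 nM.

Compound 3 and compound 1 give numbers within the scatter of each other, a 1.2-fold lower number from compound 1 to compound 3 (0.07 log units; within the scatter), while compound 2 sits at a limit. Compound 4 `NC(=S)N/N=C/c1ccc(OCC2CCCCC2)c2ccccc12` differs from compound 3 by cyclohexyl in place of phenyl on a saturated chain carbon bound to an oxygen on an aromatic ring. Among the compounds with values here, the steps that bear on this are an at least 7.4-fold lower number from compound 2 to compound 3 (0.86 log units; beyond the scatter) and an at least 6.2-fold higher number from compound 1 to compound 2 (0.79 log units; beyond the scatter), where compound 2, with its saturated chain, stands at the limit of > 200000 nM in this assay, at which 1 of the 3 values shown sits. Compound 4 carries a saturated ring in place of the aromatic one, so a higher number is expected, a 3.0-fold higher number from compound 3 to compound 4 (0.47 log units; beyond the scatter), though a ring is retained. Compound 4 is therefore estimated at 80000 nM, between 25000 nM and 200000 nM.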

Compound 4, half-maximal effective concentration: 150000 nM
The estimate for compound 4 lay 1.9-fold (0.27 log units) below the measured number; the measured number falls inside the stated range.
By their numbers in this assay, from the lowest: compounds 3 and 1 (each within the scatter of the next); then compound 4. At a limit, above all of these: compound 2.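

In this assay, cyclohexyl in place of phenyl on a saturated chain carbon bound to an oxygen on an aromatic ring gives a 5.6-fold higher number from compound 3 to compound 4 (0.74 log units; beyond the scatter), a modest step. The cyclohexylmethoxy group also gave a 4.7-fold higher number from compound 1 to compound 4 (0.67 log units; beyond the scatter) even though benzyloxy in compound 3 stayed within the scatter of methyl in compound 1. Compound 2 stands at a limit: the limit of > 200000 nM in this assay, at which 1 of the 4 values shown sits. Cyclohexyl in place of propyl on this chain carbon gives an at least 1.3-fold lower number from compound 2 to compound 4 (0.12 log units; that floor lies within the scatter).

Going by these compounds, whether a phenyl ring bearing an amine or a carboxylic acid, or a longer chain ending in phenyl, would stay near compound 3 remains open.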